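Replacing pyrimidin-5-yl with 1-methyl-1H-imidazol-4-yl: what to expect

A few compounds are considered here, and "the series" means these few. Any claim that something is new, unique, unknown or untested is made for them only; others in the source may bear on it.

In a functional assay on A549 cells (Homo sapiens) for inhibition, read by MTT assay, with a stated time of 48 h (a lower number here means a stronger inhibitor, a higher number a weaker inhibitor), compound 1 `O=C(Nc1ccncc1)Nc1cc(-c2cccnc2)ccc1OC(F)(F)F` gives 39800 nM. Within the data shown here, compound 3 `O=C(Nc1ccncc1)Nc1cc(-c2cncnc2)ccc1OC(F)(F)F` gives 3750 nM, the lowest number measured so far. Compound 2 `COc1ccc(-c2ccc(OC(F)(F)F)c(NC(=O)Nc3ccncc3)c2)cn1` returns no number, only a limit of the assay, > 300000 nM.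

Compound 4 `Cn1cnc(-c2ccc(OC(F)(F)F)c(NC(=O)Nc3ccncc3)c2)c1` has not yet been measured. It carries 1-methyl-1H-imidazol-4-yl in place of pyrimidin-5-yl on an aromatic carbon, para to a trifluoromethoxy group: 1-methyl-1H-imidazol-4-yl in place of pyrimidin-5-yl on an aromatic carbon.

All three measured steps alter the group at this same place. Pyrimidin-5-yl in place of pyridin-3-yl gives an 11-fold lower number from compound 1 to compound 3 (1.03 log units; beyond the scatter). Methoxy in place of hydrogen gives an at least 7.5-fold higher number from compound 1 to compound 2 (0.87 log units; beyond the scatter). Pyrimidin-5-yl in place of 6-methoxypyridin-3-yl gives an at least 80-fold lower number from compound 2 to compound 3 (1.90 log units; beyond the scatter). All three lie beyond the scatter, so among these compounds the group here matters considerably. None of them introduces a five-membered ring, however, so they guide the size of the next step better than its direction.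

Both other groups gave higher numbers than compound 3 at 3750 nM, so a higher number is the likelier outcome, with a clear but not extreme change. The expected change is a 4.0-fold higher number from compound 3 to compound 4 (0.60 log units; beyond the scatter). In this assay, the estimated value for compound 4 is 15000 nM, with an expected range from 2500 nM to 90000 nM.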

Compound 4, half-maximal inhibitory concentration: 79300 nM
The estimate for compound 4 lay 5.3-fold (0.72 log units) below the measured number, within the range that was stated.
By their numbers in this assay, from the lowest: compound 3; then compounds 1 and 4 (each within the scatter of the next). At a limit, above all of these: compound 2.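

In this assay, 1-methyl-1H-imidazol-4-yl brings a five-membered aromatic ring to this position for the first time among these compounds, and it gives a 21-fold higher number from compound 3 to compound 4 (1.33 log units; beyond the scatter), even though the heavy-atom, donor and acceptor counts match those of pyrimidin-5-yl, so matching those counts does not keep the number of compound 3. Against pyridin-3-yl, the same group gives a 2.0-fold higher number from compound 1 to compound 4 (0.30 log units; within the scatter), so these two groups cannot be told apart in this assay, and among the groups with a measured number, pyrimidin-5-yl alone stands apart from them. The comparison with 6-methoxypyridin-3-yl gives only a minimum size, an at least 3.7-fold lower number from compound 2 to compound 4 (0.57 log units; beyond the scatter), as compound 2 has a limit and not a number: the limit of > 300000 nM in this assay, at which 1 of the 4 values shown sits.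

The compounds shown leave open whether the step from pyrimidin-5-yl follows the change of ring or the added methyl, as none carries the five-membered ring without that methyl. They also leave open how an amine or a carboxylic acid on the pyrimidin-5-yl ring would read in this assay.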